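The compounds below may be only part of what the source reports. "The series", "measured", "known", "first", "only" and "open" are said of these compounds alone.

In a functional assay on K562 cells (Homo sapiens) for inhibition, read by MTT assay, with a stated time of 5 days (a higher number here means a weaker inhibitor, a lower number a stronger inhibitor), compound 1 `COc1ccc(/C=C2\Oc3cc(OC)c(OC)c(OC)c3C2=O)cc1O` gives 18000 nM. Compound 2 `COc1ccc(/C=C2\Oc3cc(OC)c(OC)c(OC)c3C2=O)cc1F` gives > 50000 nM, which is a limit of the assay and not a number. Compound 2 thus stands at the limit of > 50000 nM in this assay, at which 1 of the 2 values shown sits. Putting fluoro in place of hydroxy on an aromatic carbon produced an at least 2.7-fold higher number from compound 1 to compound 2 (0.44 log units; beyond the scatter). Compound 3 `COc1cc2c(c(OC)c1OC)C(=O)/C(=C/c1cc(F)c(OC)c(F)c1)O2` carries one further change, fluoro in place of hydrogen on an aromatic carbon. Among the compounds with values here, only one measured step bears on this change, and it replaced hydroxy rather than hydrogen, so it offers limited guidance. With an at least 2.7-fold higher number from compound 1 to compound 2 (0.44 log units; beyond the scatter) as the only reference, no clear gain in this assay is expected, and compound 3 should remain a weak inhibitor. The expected size of the change is a number no higher from compound 2 to compound 3 (the limit leaves the size open). For compound 3, the estimated value is 50000 nM, with an expected range of 15000 nM to 150000 nM.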

Compound 3, half-maximal inhibitory concentration: > 50000 nM
Compound 3: only a limit was reported (the forecaster's own chance of this, stated with the estimate: 60%); the middle value sits exactly at the limit.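

Compound 2 and compound 3 both stop at a limit of the assay rather than at a number, so no step between them can be read: the limit of > 50000 nM in this assay, at which 2 of the 3 values shown sit.

The compounds shown leave open how far fluoro in place of hydrogen on an aromatic carbon changes inhibition in this assay, or in which direction.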